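The compounds below may be only part of what the source reports. "The series", "measured", "known", "first", "only" and "open" are said of these compounds alone.

In a functional assay on Bel-7402 cells (Homo sapiens) for inhibition, read by MTT assay, with a stated time of 24 h, tested at 10 ug/mL (on this read-out higher numbers stand for more inhibition of growth at the one concentration tested and lower numbers for less inhibition of growth), three compounds have been examined so far. Compound 1 (`O=C(O)CCCCC(CCSC(=O)c1ccccc1)SC(=O)c1ccccc1`) gives 2.76% in that measurement. Compound 2 (`O=C(CCCCC(S)CCS)NO`) gives 28.2% there, which is the higher of the two numbers and stands beyond the scatter from compound 1. Compound 3 (`O=C(CCCCC1CCSS1)Nc1ccc([N+](=O)[O-])c(C(F)(F)F)c1`) is recorded as "not active" (no number reported) and carries no number.

Compound 4 (`O=C(CCCCC(S)CCS)Nc1ccccc1`) has not yet been measured. It departs from compound 2 by a single change, phenyl in place of hydroxy on an amide-type nitrogen. Going by the values given here, no measured pair isolates this change, so the expectation is a loose one. Among the compounds with values here, the only other tested compound with a ring on its amide nitrogen is compound 3, entered as "not active" (no number reported), though it also differs elsewhere. A moderate fall in this assay is therefore expected. The estimated change is a number 13.2 percentage points lower from compound 2 to compound 4 (beyond the scatter) in this account. For compound 4 the estimate is 15% within an expected range of 3% to 32% in this assay as the likely outcome.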

Compound 4, percent growth inhibition at one concentration: 3.72%
Estimate against measurement, compound 4: 11.3 percentage points above, and the stated range covers the measured number.
By their numbers in this assay, from the lowest: compounds 1 and 4 (each within the scatter of the next); then compound 2.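

Phenyl in place of hydroxy on an amide-type nitrogen gives a number 24.5 percentage points lower from compound 2 to compound 4 (beyond the scatter) in this assay. Going by these compounds alone, this is the first pair among the compounds that isolates a change at this nitrogen, and it shows that, with the rest of the structure held constant, the substituent there alters growth inhibition at the one concentration tested, with the hydroxy form giving the higher number. No measurement is available that would explain the step.

The compounds shown leave open whether the fall follows from the loss of hydroxy or from the arrival of phenyl, as this single exchange changes both at once. Also open, as far as these compounds go, is how a methyl or a benzyl group on the same nitrogen would read in this assay.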